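This account rests on a few compounds, and the source may have more. Where it says the series, first, only, none or still open, it means among the compounds named here.

Three compounds share one core and differ only in the aryl group attached to an aromatic carbon. Compound 1 `O=c1ncn(Cc2c(F)cc(F)cc2F)c2ccc(Oc3cccc(-c4ccc5[nH]cnc5c4)c3C(F)(F)F)cc12` gives 4.7 in a physicochemical assay for lipophilicity, at pH 7.4; on this read-out lower numbers stand for lower lipophilicity and higher numbers for higher lipophilicity. Compound 2 `O=c1ncn(Cc2c(F)cc(F)cc2F)c2ccc(Oc3cccc(-c4ccc5cc[nH]c5c4)c3C(F)(F)F)cc12` gives 5 in this assay, and the step of a number 0.30 log units higher from compound 1 to compound 2 (within the scatter) lies within the scatter. Compound 3 `Nc1ccc(-c2cccc(Oc3ccc4c(c3)c(=O)ncn4Cc3c(F)cc(F)cc3F)c2C(F)(F)F)cn1` gives 3.9 in this assay, the lowest of the three numbers; the steps of a number 0.80 log units lower from compound 1 to compound 3 (beyond the scatter) and a number 1.10 log units lower from compound 2 to compound 3 (beyond the scatter) are both beyond the scatter.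

Compound 4 `Cc1cc(-c2cccc(Oc3ccc4c(c3)c(=O)ncn4Cc3c(F)cc(F)cc3F)c2C(F)(F)F)cnc1N` is not yet measured in this assay. It differs from compound 3 by methyl in place of hydrogen on an aromatic carbon. Among the compounds with values here, none of the measured steps bears directly on this change: each of them swaps one whole aryl group for another, whereas here a single methyl enters. Adding a carbon without donors or acceptors usually nudges this read-out a little upward, so for compound 4 the step of a number 0.40 log units higher from compound 3 to compound 4 (beyond the scatter) is expected, small and possibly within the scatter. The estimate for compound 4 in this assay is 4.3, between 3.9 and 4.7.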

Compound 4, distribution coefficient: > 4.7
Compound 4 gave a limit, no number; the forecaster's own chance of this, stated with the estimate: 2%; middle value at least 0.40 log units away from the limit.
By their numbers in this assay, from the lowest: compound 3; then compounds 1 and 2 (each within the scatter of the next).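

In this assay compound 4 gives a limit of the assay and not a number: the limit of > 4.7 in this assay, at which 1 of the 4 values shown sits. A single methyl, ortho to an amino group and two atoms from the ring nitrogen, gives a number at least 0.80 log units higher from compound 3 to compound 4 (beyond the scatter), so at this position one added carbon moves the read-out at least as far as the exchange of a whole aryl group in a number 0.80 log units lower from compound 1 to compound 3 (beyond the scatter). The 6-amino-5-methylpyridin-3-yl group also gives a number no lower from compound 1 to compound 4 (the limit leaves the size open), while the step from compound 2 cannot be read.

On these data alone, the actual number for compound 4, and with it the full size of the methyl step, stays open. Also open, as far as these compounds go, is how an ethyl group, a methoxy group or a fluorine atom at this same place would change the read-out.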